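The source may report more compounds than this note shows. Statements on the series, on what has been measured and on what is new or still open speak of the compounds shown alone.

Working notes on this series, with all numbers taken from a functional assay on BXPC-3 cells (Homo sapiens) for cytotoxicity, read by fluorescence, with a stated time of 48 h (on this read-out lower numbers stand for an effect already at smaller amounts and higher numbers for an effect only at larger amounts of compound), as the only read-out. Compound 1 (`CC(C)=CCC/C(C)=C/CC/C(C)=C/CSC[C@H](NC(=O)CCCCCN1CCN(C)CC1)C(=O)NC1CC1`) gives 6300 nM and compound 2 (`CC(C)=CCC/C(C)=C/CC/C(C)=C/CSC[C@H](NC(=O)CCCCCN1CCCC1)C(=O)N1CCCCC1`) gives 8700 nM in the same test. Among the measured compounds shown here, compound 2 therefore sits within the scatter of compound 1, the only other number available, and no order can be read between them. For the measured compounds named here, no step in a single place joins the two measured compounds, so the effect of one change alone has not yet been seen.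

Compound 3 (`CC(C)=CCC/C(C)=C/CC/C(C)=C/CSC[C@H](NC(=O)CCCCCN1CCN(C)CC1)C(=O)N1CCCCC1`) departs from compound 2 in one place, 4-methylpiperazin-1-yl in place of pyrrolidin-1-yl on a saturated chain carbon, five bonds along the chain from a carbonyl carbon with 4-methylpiperazin-1-yl in place of pyrrolidin-1-yl on a saturated chain carbon, five bonds along the chain from a carbonyl carbon. The entering group is already carried by compound 1 at 6300 nM and compound 2 at 8700 nM lies within the scatter of it, so no move beyond the scatter is expected in this assay in either direction. The estimated outcome is a 1.2-fold lower number from compound 2 to compound 3 (0.06 log units; within the scatter) and no more than that. Compound 3 is estimated at 7500 nM with 3500 nM and 16000 nM as the expected ends of the range.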

Compound 3, half-maximal effective concentration: 8800 nM
Estimate against measurement, compound 3: 1.2-fold (0.07 log units) below; low and high end bracket the measured number.
By their numbers in this assay, from the lowest: compounds 1, 2 and 3 (each within the scatter of the next).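

In this assay the exchange of pyrrolidin-1-yl for 4-methylpiperazin-1-yl on a saturated chain carbon, five bonds along the chain from a carbonyl carbon, gives a 1.0-fold higher number from compound 2 to compound 3 (0.00 log units; within the scatter) and so leaves no readable effect at this position, with piperidin-1-yl held on the carbonyl carbon. The other single-place step, piperidin-1-yl in place of cyclopropylamino on a carbonyl carbon, gives a 1.4-fold higher number from compound 1 to compound 3 (0.15 log units; within the scatter) and also stays within the scatter, so with 4-methylpiperazin-1-yl held on the chain, neither end of the molecule has yet shown a change that can be read. No measurement bearing on the reason for these results is at hand.

Still open, on these data alone, is whether an open-chain amine such as dimethylamino in place of these rings, or a shorter or longer chain carrying the same rings, would move the number beyond the scatter. It is equally open whether a free carboxylic acid in place of the amide on the carbonyl carbon would do so, since the three amine and amide pairings shown cover only a small part of what these two places could carry.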